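A few compounds are considered here, and "the series" means these few. Any claim that something is new, unique, unknown or untested is made for them only; others in the source may bear on it.

Measured so far in a physicochemical assay for lipophilicity, at pH 7.4; on this read-out lower numbers stand for lower lipophilicity and higher numbers for higher lipophilicity:
compound 1 `Cc1cccc2c(NCc3ccco3)nc(NC(C)C)nc12` gives 3.55
compound 2 `Cc1ccc2nc(NC(C)C)nc(NCc3ccco3)c2c1` gives 3.63
compound 3 `COc1cccc2c(NCc3ccco3)nc(NC(C)C)nc12` gives 3.4

Compound 1 and compound 2 are built from the same atoms joined differently; the difference between the two cores is not broken down here, and their two values in this assay lie within the scatter of each other. Compound 3 carries methoxy in place of methyl on an aromatic carbon relative to compound 1, and the step is a number 0.15 log units lower from compound 1 to compound 3 (within the scatter).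

Compound 4 `COc1ccc2nc(NC(C)C)nc(NCc3ccco3)c2c1` is not yet measured. It carries methoxy in place of methyl on an aromatic carbon relative to compound 2. For the measured compounds named here, this is the same kind of change as the one from compound 1 to compound 3, but the place differs: in compound 3 the group sits ortho to a fused ring and meta to a fused ring, in compound 4 meta to a fused ring and para to a fused ring.

From compound 2 to compound 4 a step of about a number 0.15 log units lower from compound 2 to compound 4 (within the scatter) is expected, resting on the step of a number 0.15 log units lower from compound 1 to compound 3 (within the scatter) seen for the same kind of change. Compound 4 is therefore estimated at 3.48, with a range of 3.25 to 3.75.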

Compound 4, distribution coefficient: 3.58
The estimate for compound 4 lay 0.10 log units below the measured number; the measured number falls inside the stated range.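

In this assay, methoxy in place of methyl on an aromatic carbon gives a number 0.05 log units lower from compound 2 to compound 4 (within the scatter), and on the other core the same change gives a number 0.15 log units lower from compound 1 to compound 3 (within the scatter). The change therefore stays within the scatter on both cores, but this does not show that the two steps are the same or different, and the effect of the core cannot be separated from that of the place, since both vary together. No measurement bearing on what lies behind these steps is at hand.

Open, from the compounds shown here alone, is whether an amine, a carboxylic acid or a longer chain on the same aromatic carbon would give a step beyond the scatter. Also open, going by these compounds, is whether either core would respond in the same way to such groups.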